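Removing the Carboxy Group from Compound 1

The source may hold more compounds than are shown below. What is called first, only, known or untested is meant among the compounds shown, and "the series" means these compounds.

compound 1, `COc1ccc2c(c1)OC(c1cc(OC)c(OC)c(OC)c1)C(C(=O)O)=C2` — > 50000 nM
compound 2, `CCCCNC(=O)C1=Cc2ccc(OC)cc2OC1c1cc(OC)c(OC)c(OC)c1` — 25500 nM
compound 3, `COc1ccc2c(c1)OC(c1cc(OC)c(OC)c(OC)c1)C(C#N)=C2` — 3400 nM

These three compounds share one core and differ only in the group on a double-bonded ring carbon. In a functional assay for inhibition of nuclear factor NF-kappa-B complex (Homo sapiens) (on this read-out higher numbers stand for weaker inhibition and lower numbers for stronger inhibition), compound 1 gives > 50000 nM, which is a limit of the assay rather than a number. Compound 2 gives 25500 nM and compound 3 gives 3400 nM. Exchanging the carboxy group of compound 1 brought an at least 1.9-fold lower number from compound 1 to compound 2 (0.29 log units; that floor lies within the scatter) and an at least 14-fold lower number from compound 1 to compound 3 (1.16 log units; beyond the scatter); between the two exchanged groups stands a 7.5-fold lower number from compound 2 to compound 3 (0.88 log units; beyond the scatter).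

Compound 4, `COc1ccc2c(c1)OC(c1cc(OC)c(OC)c(OC)c1)C=C2`, takes a further route: hydrogen in place of carboxy on a double-bonded ring carbon. Both measured steps away from the carboxy group lowered the number, one of them by a large step, and so compound 4 is expected to give a lower number than compound 1, though where between the two measured exchanges the hydrogen falls cannot be told from these numbers. Compound 4 is expected to give 15000 nM in this assay, with a range from 3000 nM to 60000 nM. For compound 4 this estimate is expected to mean an at least 3.3-fold lower number from compound 1 to compound 4 (0.52 log units; beyond the scatter).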

Compound 4, half-maximal inhibitory concentration: 17700 nM
Compound 4: the middle estimate sits 1.2-fold (0.07 log units) below what was measured, and the stated range covers the measured number.
By their numbers in this assay, from the lowest: compound 3; then compounds 4 and 2 (each within the scatter of the next). At a limit, above all of these: compound 1.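

Going by these compounds alone, compound 4 carries only hydrogen on the double-bonded ring carbon, which gives this position in this assay a reference point that the earlier compounds did not offer. Taking the carboxy group away with no other group entering already brings an at least 2.8-fold lower number from compound 1 to compound 4 (0.45 log units; beyond the scatter), and this size is only a floor, because the value at the carboxy end is a limit of the assay: the limit of > 50000 nM in this assay, at which 1 of the 4 values shown sits. Butylcarbamoyl and hydrogen cannot be told apart here, with a 1.4-fold lower number from compound 2 to compound 4 (0.16 log units; within the scatter), whereas the cyano group does stand apart, with a 5.2-fold higher number from compound 3 to compound 4 (0.72 log units; beyond the scatter), so among the four groups shown cyano alone gives a lower number than hydrogen.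

The compounds shown leave open whether that lower number is particular to the cyano group or would also be seen with other groups on this carbon, such as a methyl ester, a primary amide or a chlorine atom. They also leave open how a shorter chain on the amide nitrogen, or an amine in that chain, would compare with hydrogen, and how far the carboxy compound really lies from the others.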